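This account rests on a few compounds, and the source may have more. Where it says the series, first, only, none or still open, it means among the compounds named here.

Measured so far in an ADME assay on HaCaT cells (Homo sapiens) for cytotoxicity, read by MTT assay, with a stated time of 72 h; on this read-out lower numbers stand for stronger inhibition and higher numbers for weaker inhibition:
compound 1 `Cc1ccc(CSc2cc(Cl)c(C)cc2S(=O)(=O)/N=C(\N)n2nc(C)cc2-c2ccccc2)cc1`: 30000 nM
compound 2 `Cc1ccc(CSc2cc(Cl)c(C)cc2S(=O)(=O)/N=C(\N)n2nccc2-c2ccccc2)cc1`: 20000 nM

Compound 1 stands highest of the two numbers shown in this assay; its nearest neighbour is compound 2, with a 1.5-fold lower number from compound 1 to compound 2 (0.18 log units; within the scatter), a change that stays within the scatter.

The step to compound 3 `Cc1cc(-c2ccccc2)n(/C(N)=N/S(=O)(=O)c2cc(C)c(Cl)cc2SCc2ccc(Cl)cc2)n1` is a different one: chloro in place of methyl on an aromatic carbon. Among the compounds with values here, no measured step touches this position; the only step in hand, from compound 1 to compound 2 by loss of a methyl on the shared core, was within the scatter, and neither measured compound varies the substituent on the benzyl ring. The record therefore gives no footing for a shift in either direction, and for compound 3 the expectation in this assay is no change at the digits printed from compound 1 to compound 3 (within the scatter), that is no step beyond the scatter.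

Compound 3 is estimated at 30000 nM, in the range 10000 nM to 90000 nM.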

Compound 3, half-maximal inhibitory concentration: 11000 nM
Estimate against measurement, compound 3: 2.7-fold (0.44 log units) above, within the range that was stated.
By their numbers in this assay, from the lowest: compounds 3, 2 and 1 (each within the scatter of the next, the first and the last beyond it).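

In this assay, within the data shown here, the change from 4-methylbenzyl to 4-chlorobenzyl gives a 2.7-fold lower number from compound 1 to compound 3 (0.44 log units; beyond the scatter) as the first step at this position, a modest one but beyond the scatter. The only earlier step, a 1.5-fold lower number from compound 1 to compound 2 (0.18 log units; within the scatter) on loss of a methyl from the shared core, stayed within the scatter, so this position on the aromatic ring is the first place in the series shown where a single change moves the number beyond it. Nothing on record explains the shift.

Still open, as far as these compounds go, is how the number responds to other groups at this position, such as a methoxy, an amine or a carboxylic acid. Also open, from the compounds shown here alone, is whether chloro in place of methyl here gives a step of similar size on the core of compound 2.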